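From Two Methoxy Groups to One: Compound 4 Estimated

A few compounds are considered here, and "the series" means these few. Any claim that something is new, unique, unknown or untested is made for them only; others in the source may bear on it.

Of the compounds shown here, three sharing one core have been tested in a functional assay on KB cells (Homo sapiens) for cytotoxicity, read by MTT assay, with a stated time of 72 h; on this read-out higher numbers stand for weaker inhibition and lower numbers for stronger inhibition. Compound 3 `COc1cc(OC)cc(/C(=C\c2cn(C(C)=O)c3ccc(OCc4ccccc4)cc23)C(=O)O)c1` gives 30400 nM in this assay. Compound 2 `COc1ccc(/C(=C\c2c[nH]c3ccc(OCc4ccccc4)cc23)C(=O)O)cc1` gives 38500 nM, which sits within the scatter of compound 3. Compound 1 `COc1cccc(/C(=C\c2cn(C(C)=O)c3ccc(OCc4ccccc4)cc23)C(=O)O)c1` reached only the limit of this assay, > 100000 nM (the limit of > 100000 nM in this assay, at which 1 of the 3 values shown sits). Among the two numbers actually obtained, compound 3 holds the lower one, and compound 2 is the nearest.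

Within the data shown here, the only measured step that changes the methoxy pattern, an at least 3.2-fold lower number from compound 1 to compound 3 (0.51 log units; beyond the scatter), shows that adding a methoxy to the ring on the chain carbon made the number fall. Compound 4 `COc1ccc(/C(=C\c2cn(C(C)=O)c3ccc(OCc4ccccc4)cc23)C(=O)O)cc1` is still unmeasured; the change from compound 3 is 4-methoxyphenyl in place of 3,5-dimethoxyphenyl on a double-bonded chain carbon bound to a carbonyl carbon and a double-bonded chain carbon. This removes one methoxy while shifting the other, so the measured step does not fit it directly, and compound 2 carries the same 4-methoxyphenyl but an unacetylated core. Compound 4 is therefore expected to land near compound 2 and compound 3, with an estimated step of a 1.6-fold higher number from compound 3 to compound 4 (0.22 log units; within the scatter) and a value of 50000 nM, ranging from 15000 nM to 150000 nM.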

Compound 4, half-maximal inhibitory concentration: > 100000 nM
Compound 4: no number, only a limit; the forecaster's own chance of this, stated with the estimate: 30%; middle value at least 2.0-fold (0.30 log units) from the limit.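

In this assay, compound 4 gives a limit of the assay and not a number: the limit of > 100000 nM in this assay, at which 2 of the 4 values shown sit.

Placing 4-methoxyphenyl in place of 3,5-dimethoxyphenyl on the double-bonded chain carbon gives an at least 3.2-fold higher number from compound 3 to compound 4 (0.51 log units; beyond the scatter), so among the compounds carrying the acetyl on the core nitrogen, only the one with 3,5-dimethoxyphenyl reaches a number. The earlier compounds shown here showed a methoxy being added at this ring; this step shows that the pattern of methoxy groups there matters too. Acetyl in place of hydrogen on the aromatic nitrogen gives an at least 2.5-fold higher number from compound 2 to compound 4 (0.41 log units; beyond the scatter), the first view of that change, and here the 4-methoxyphenyl compound reaches a number only with the hydrogen.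

The step between compound 1 and compound 4 cannot be read, so the two single-methoxy patterns stay unranked. On these data alone, whether a hydroxyl or an amine on this ring would give a number in this assay remains open, as does the effect of the acetyl with 3,5-dimethoxyphenyl.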